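The compounds below may be only part of what the source reports. "The series", "measured", "known", "first", "only" and "open" are said of these compounds alone.

Three ureas built on a shared core were examined in an ADME assay on the whole organism with Oryza sativa as the target, tested at 10 uM; on this read-out higher numbers stand for a weaker effect at the one concentration tested and lower numbers for a stronger effect. Compound 1 `CC(C)c1ccccc1NC(=O)N[C@@H](C)c1ccccc1` gives 93% in this assay. Compound 3 `C[C@H](NC(=O)Nc1ccccc1C(F)(F)F)c1ccccc1` differs from compound 1 by trifluoromethyl in place of isopropyl on an aromatic carbon; compound 3 gives 97%, and the step of a number 4 percentage points higher from compound 1 to compound 3 (within the scatter) is accordingly small. Compound 2 `CC(C)c1cccc(NC(=O)N[C@H](C)c2ccccc2)c1` gives 44%, the lowest of the three numbers, with its nearest neighbour compound 1 standing well beyond the scatter above it. The difference between the core of compound 2 and the core of compound 1 is not broken down here; the two have the same atoms joined differently.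

Compound 4 `C[C@@H](NC(=O)Nc1cccc(C(F)(F)F)c1)c1ccccc1` has not yet been measured. Relative to compound 2 it carries trifluoromethyl in place of isopropyl on an aromatic carbon, the same kind of change as that seen from compound 1 to compound 3, but not the same: in compound 4 the place is meta to a large group, whereas in compound 3 it is ortho to a large group. Among these compounds the change is seen in one measured pair and in one pair not yet measured.

Because the step of a number 4 percentage points higher from compound 1 to compound 3 (within the scatter) lies within the scatter, the step expected to compound 4 is a number 6 percentage points higher from compound 2 to compound 4 (within the scatter). Among the measured compounds shown here, the differing place and the single measured example make this expectation less secure than the measured step. For compound 4 the estimate in this assay is 50%, expected to fall between 30% and 75%.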

Compound 4, a percentage reported as activity, at one concentration (the size of the read-out at that concentration, not a potency): 70%
The estimate for compound 4 lay 20 percentage points below the measured number, within the range that was stated.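

In this assay, the exchange of isopropyl for trifluoromethyl did not carry over from one core to the other with the same size of step: the same change on two cores in this assay, a number 4 percentage points higher (within the scatter) from compound 1 to compound 3 and a number 26 percentage points higher (beyond the scatter) from compound 2 to compound 4, 22 percentage points apart, beyond the scatter of two such steps. On the core of compound 2 the exchange gave a number 26 percentage points higher from compound 2 to compound 4 (beyond the scatter), so there it went with a weaker effect at the one concentration tested, and a step read on the core of compound 1 would not have served as a reliable guide to the step on this core. This does not show why the two steps part, nor how the change would behave on any further core, since the comparison rests on a single pair for each core, and the core of compound 2 offers only one place, meta to a large group, for the exchange.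

The compounds shown carry only isopropyl and trifluoromethyl on the aromatic ring, which leaves open whether a methyl, a chlorine or a methoxy group in the same place would follow the small step or the larger one. They also leave open what an amine or a carboxylic acid there would do to the read-out, and whether the gap between the two cores would persist with such groups.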